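Phenyl to Pyridin-4-yl on Two Related Cores

This account rests on a few compounds, and the source may have more. Where it says the series, first, only, none or still open, it means among the compounds named here.

Compound 1, `O=S(=O)(c1ccccc1)n1ccc2c(-c3ccccc3)cccc21`, is the reference point. In an assay on isolated protein for displacement of a labelled ligand from 5-hydroxytryptamine receptor 6 (Homo sapiens), read by scintillation counting, with a stated time of 1 h (on this read-out lower numbers stand for stronger inhibition and higher numbers for weaker inhibition), compound 1 gives 162 nM. Compound 2, `O=S(=O)(c1ccccc1)n1ccc2c(-c3ccncc3)cccc21`, differs from it by pyridin-4-yl in place of phenyl on an aromatic carbon and in this assay compound 2 gives 1510 nM, so the step is a 9.3-fold higher number from compound 1 to compound 2 (0.97 log units; beyond the scatter). Compound 3, `O=S(=O)(c1ccccc1)n1ccc2cc(-c3ccccc3)ccc21`, is built from the same atoms as compound 1 joined differently; the difference between the two cores is not broken down here. In this assay compound 3 gives 558 nM. Compound 4, `O=S(=O)(c1ccccc1)n1ccc2cc(-c3ccncc3)ccc21`, has not been measured and differs from compound 3 by pyridin-4-yl in place of phenyl on an aromatic carbon. Going by the values given here, this is the same kind of change as the one from compound 1 to compound 2, but the place is not identical: on the core of compound 1 the group sits ortho to a fused ring and meta to a fused ring, while on the core of compound 3 it sits meta to a fused ring and para to a fused ring. Because the earlier change gave a 9.3-fold higher number from compound 1 to compound 2 (0.97 log units; beyond the scatter), the expected step here is an 8.1-fold higher number from compound 3 to compound 4 (0.91 log units; beyond the scatter), with extra uncertainty from the different place. Compound 4 is therefore estimated to give about 4500 nM in this assay, between 1500 nM and 13000 nM.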

Compound 4, inhibition constant: 409 nM
For compound 4 the middle estimate is 11-fold (1.04 log units) above the measured one; the measured number lies below the stated range.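

On the core of compound 3, putting pyridin-4-yl in place of phenyl gives a 1.4-fold lower number from compound 3 to compound 4 (0.13 log units; within the scatter), so the two compounds cannot be told apart in this assay. The swap therefore does not carry over unchanged from the core of compound 1 to the core of compound 3: the same change on two cores in this assay, a 9.3-fold higher number (0.97 log units; beyond the scatter) from compound 1 to compound 2 and a 1.4-fold lower number (0.13 log units; within the scatter) from compound 3 to compound 4, 13-fold (1.10 log units) apart, beyond the scatter of two such steps. Going by these compounds alone, this shows that, for these two cores, the result of the swap on one core does not predict its result on the other, but with only two pairs it does not show which difference between the cores is responsible, or whether the same would hold on any further core.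

The compounds shown leave open how other groups in the same place, such as pyridin-3-yl, an amine or a carboxylic acid, would behave on each core. They also leave open whether the difference between the two cores would appear in any measurement other than this assay.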